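Chain-end aryl swap: working notes toward compound 4

This account rests on a few compounds, and the source may have more. Where it says the series, first, only, none or still open, it means among the compounds named here.

Measured so far in an assay on CHO cells for displacement of a labelled ligand from muscarinic acetylcholine receptor M5 (Homo sapiens), read by scintillation counting, with a stated time of 2 h; a higher number here means a weaker inhibitor, a lower number a stronger inhibitor:
compound 1 `O=C(OCCc1ccc(Cl)c(Cl)c1)N(c1ccccc1)C1CN2CCC1CC2`, compound 1 gives 80 nM
compound 2 `COc1ccc(CCOC(=O)N(c2ccccc2)C2CN3CCC2CC3)cc1`, compound 2 gives 230 nM
compound 3 `Cc1ccc(CCCOC(=O)N(c2ccccc2)C2CN3CCC2CC3)cc1F`, compound 3 gives 130 nM

Compound 3 sits second highest of the three numbers. Its nearest neighbour is compound 1, with a 1.6-fold higher number from compound 1 to compound 3 (0.21 log units; within the scatter), and its furthest is compound 2, with a 1.8-fold lower number from compound 2 to compound 3 (0.25 log units; within the scatter); both gaps lie within the scatter, so no order among compound 1, compound 3 and compound 2 can be read from them. Going by the values given here, the one step that stands beyond the scatter is a 2.9-fold higher number from compound 1 to compound 2 (0.46 log units; beyond the scatter), a modest rise.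

Compound 4 `COc1ccc(CCCOC(=O)N(c2ccccc2)C2CN3CCC2CC3)cc1` differs from compound 3 by 4-methoxyphenyl in place of 3-fluoro-4-methylphenyl on a saturated chain carbon, three bonds along the chain from an oxygen next to a carbonyl group. Among the compounds with values here, two measured steps bear on it. The swap of a halogenated ring for the 4-methoxyphenyl on the shorter chain, a 2.9-fold higher number from compound 1 to compound 2 (0.46 log units; beyond the scatter), gave a modest rise. The move from compound 2 to compound 3, a 1.8-fold lower number from compound 2 to compound 3 (0.25 log units; within the scatter), changes both ring and chain length and stays within the scatter. Taken together, a small rise toward the value of compound 2 is expected, likely near or just beyond the scatter. For compound 4 the expected step is a 1.5-fold higher number from compound 3 to compound 4 (0.19 log units; within the scatter). The estimate for compound 4 in this assay is 200 nM, with a range of 90 nM to 450 nM.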

Compound 4, inhibition constant: 640 nM
Compound 4: the middle estimate sits 3.2-fold (0.51 log units) below what was measured, outside the stated range (above it).
By their numbers in this assay, from the lowest: compounds 1, 3 and 2 (each within the scatter of the next, the first and the last beyond it); then compound 4.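

In this assay the 4-methoxyphenyl ring now carries the higher number at both chain lengths: on the longer chain, 4-methoxyphenyl in place of 3-fluoro-4-methylphenyl gives a 4.9-fold higher number from compound 3 to compound 4 (0.69 log units; beyond the scatter), a step that matches the direction of the one on the shorter chain, although the ring replaced differs between the two pairs. The series also gains its first step in chain length alone, with the ring held: 4-methoxybenzyl in place of 4-methoxyphenyl gives a 2.8-fold higher number from compound 2 to compound 4 (0.44 log units; beyond the scatter), so at this position the chain, and not only the ring, moves the number. Compound 4 thus stands as the weakest of the four, with an 8.0-fold higher number from compound 1 to compound 4 (0.90 log units; beyond the scatter) as the widest step in the series, and no data shown here account for these rises.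

Going by these compounds, the chain step is read only with the 4-methoxyphenyl ring, so whether the 3,4-dichlorophenyl or 3-fluoro-4-methylphenyl rings respond to chain length in the same way stays open. Also open, on these data alone, is how a still longer chain, or a ring carrying a nitrile or an amine instead of the methoxy group, would behave at this position.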